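Swapping an amide for a sulfonyl on a piperidine nitrogen

A few compounds are considered here, and "the series" means these few. Any claim that something is new, unique, unknown or untested is made for them only; others in the source may bear on it.

Compound 1 `O=C(CCCC1CCN(S(=O)(=O)CCc2ccccc2)CC1)c1ncco1`: in an assay on isolated protein for inhibition of Fatty-acid amide hydrolase 1 (Homo sapiens) (on this read-out higher numbers stand for weaker inhibition and lower numbers for stronger inhibition), compound 1 gives 6 nM
Compound 2 `CC(C)C(=O)N1CCC(CCCC(=O)c2ncco2)CC1`: in this assay compound 2 gives 250 nM
Compound 3 `CC(C)(C)CC(=O)N1CCC(CCCC(=O)c2ncco2)CC1`: in this assay compound 3 gives 90 nM

Three compounds share the same core and differ only in the group that caps the ring nitrogen. Compound 3 stands second of the three numbers: below compound 2 and well above compound 1. Within the data shown here, the one step measured between neighbours, a 2.8-fold lower number from compound 2 to compound 3 (0.44 log units; beyond the scatter), shows that enlarging the chain on the carbonyl carbon lowered the number by a modest amount.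

Compound 4 `CC(C)S(=O)(=O)N1CCC(CCCC(=O)c2ncco2)CC1` has not been measured. The change from compound 3 is isopropylsulfonyl in place of neopentylcarbonyl on an amine nitrogen in a ring. Two threads bear on it. First, compound 4 carries the same isopropyl seen in compound 2, and the step of a 2.8-fold lower number from compound 2 to compound 3 (0.44 log units; beyond the scatter) suggests that losing the larger neopentyl tends to push the number back up. Second, compound 1, the only sulfonyl-capped compound, gives the lowest number of the set, though it differs from compound 3 in more than one place, so no single step can be read from it. Weighing both, compound 4 is expected to land near compound 3, perhaps slightly lower, with a step of a 1.5-fold lower number from compound 3 to compound 4 (0.18 log units; within the scatter) that may not exceed the scatter. The estimate for compound 4 is 60 nM, within 15 nM to 300 nM.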

Compound 4, half-maximal inhibitory concentration: 140 nM
Beside the measured number, compound 4's estimate is 2.3-fold (0.37 log units) below it, and the stated range covers the measured number.
By their numbers in this assay, from the lowest: compound 1; then compounds 3, 4 and 2 (each within the scatter of the next, the first and the last beyond it).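

With the isopropyl kept and only the carbonyl exchanged for a sulfonyl, this assay shows a 1.8-fold lower number from compound 2 to compound 4 (0.25 log units; within the scatter) and so does not separate the two caps, and the exchange of neopentylcarbonyl for isopropylsulfonyl, at a 1.6-fold higher number from compound 3 to compound 4 (0.19 log units; within the scatter) and on the same ring nitrogen, does not separate them either. The large change appears only when the sulfonyl stays and the group on its sulfur changes, with a 23-fold higher number from compound 1 to compound 4 (1.37 log units; beyond the scatter) as phenethyl gives way to isopropyl, so a sulfonyl on this nitrogen does not by itself bring the low number of compound 1, and the group it carries matters far more here. Nothing at hand explains why these numbers fall as they do.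

The compounds shown leave open whether a phenethyl on a carbonyl carbon would give a number as low as the same group does on a sulfonyl sulfur. Also open, as far as these compounds go, is how other groups on that sulfur, such as a benzyl, a longer phenylpropyl chain or a neopentyl, would compare with phenethyl and isopropyl.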